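A Phenyl Group Replaces the Branched Chain

The source may report more compounds than this note shows. Statements on the series, on what has been measured and on what is new or still open speak of the compounds shown alone.

The account concerns three compounds measured in a functional assay on the whole organism (blood, strain Wistar-Okamoto) with Rattus norvegicus as the target, with a stated time of 5 days (on this read-out lower numbers stand for an effect already at smaller amounts and higher numbers for an effect only at larger amounts of compound), and a fourth that has not been. Compound 1 `N#CN/C(=N\C1CCCC1)Nc1cccnc1` gives 20 mg/kg in this assay, and compound 2 `N#CN/C(=N\C1CCCCC1)Nc1cccnc1` gives 20 mg/kg, so that no change at the digits printed from compound 1 to compound 2 (within the scatter). Compound 3 `CC(C)C(C)(C)/N=C(\NC#N)Nc1cccnc1` gives 1 mg/kg and holds the lowest of the three numbers: a 20-fold lower number from compound 1 to compound 3 (1.30 log units; beyond the scatter), and likewise a 20-fold lower number from compound 2 to compound 3 (1.30 log units; beyond the scatter). Compound 4 `N#CN/C(=N\c1ccccc1)Nc1cccnc1` differs from compound 3 in one place: phenyl in place of 1,1,2-trimethylpropyl on a double-bonded nitrogen. Within the data shown here, no measured step exchanges a branched chain for an aromatic ring, so the earlier steps bear on this one only indirectly. Both steps leading to compound 3 replaced a ring with the 1,1,2-trimethylpropyl group and lowered the number by a large amount; putting a ring back on the double-bonded nitrogen therefore points toward higher numbers again, although a phenyl is neither a cyclopentyl nor a cyclohexyl. Compound 4 is accordingly expected to show a 15-fold higher number from compound 3 to compound 4 (1.18 log units; beyond the scatter). Compound 4 is estimated at 15 mg/kg, within a range from 4 mg/kg to 60 mg/kg.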

Compound 4, minimum effective dose: 5 mg/kg
Estimate against measurement, compound 4: 3.0-fold (0.48 log units) above; measured number inside the range.
By their numbers in this assay, from the lowest: compound 3; then compound 4; then compounds 1 and 2 (each within the scatter of the next).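

In this assay, the double-bonded nitrogen tolerates an aromatic ring better than either saturated ring, with a 4.0-fold lower number from compound 1 to compound 4 (0.60 log units; beyond the scatter) and a 4.0-fold lower number from compound 2 to compound 4 (0.60 log units; beyond the scatter) as the two steps from those rings. A ring at this place therefore does not in itself bring the higher numbers seen for compound 1 and compound 2, and the kind of ring matters. The branched chain still holds the lowest number, with a 5.0-fold higher number from compound 3 to compound 4 (0.70 log units; beyond the scatter) despite the same heavy-atom count in the leaving and entering groups, and nothing offered here explains these differences.

The compounds shown leave open whether a benzyl group or a chlorine-bearing phenyl would fall nearer to compound 3 or to compound 4. They also leave open how a straight hexyl chain would compare with the branched 1,1,2-trimethylpropyl group at this place.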